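Bromo to methyl swap on the shared core

A few compounds are considered here, and "the series" means these few. Any claim that something is new, unique, unknown or untested is made for them only; others in the source may bear on it.

Two members of the series have been run in an ADME assay on MCF-10A cells (Homo sapiens) for cytotoxicity, read by MTT assay, with a stated time of 24 h; on this read-out higher numbers stand for weaker inhibition and lower numbers for stronger inhibition. Compound 1 `Brc1ccc(-c2cc(COc3ccccc3-c3nc4ccccc4s3)on2)cc1` gives 29200 nM in that test, and compound 2 `FC(F)(F)C(F)(F)C(F)(F)C(F)(F)C(F)(F)C(F)(F)C(F)(F)C(F)(F)CCn1cc(COc2ccccc2-c2nc3ccccc3s2)nn1` gives 33100 nM. Compound 1 holds the lower of the two numbers, yet its nearest neighbour, compound 2, lies within the scatter of it, so the two read-outs cannot be told apart. Among the measured compounds shown here, no pair of measured compounds differs in a single place, and so no measured step gives a size for any one structural change.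

Compound 3 `Cc1ccc(-c2cc(COc3ccccc3-c3nc4ccccc4s3)on2)cc1` is the next one to be measured in this assay. It differs from compound 1 in one place: methyl in place of bromo on an aromatic carbon, para to a large group, with the shared core otherwise unchanged. For the measured compounds named here, with no measured step of this kind on hand, the expectation rests on the two measured values alone, which sit close together. The change is expected to be small, estimated at a 1.2-fold higher number from compound 1 to compound 3 (0.08 log units; within the scatter), leaning toward a somewhat higher number but not clearly beyond the scatter. Compound 3 is therefore expected to give about 35000 nM, within a range of 15000 nM to 80000 nM.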

Compound 3, half-maximal inhibitory concentration: 26400 nM
Compound 3: middle estimate off by 1.3-fold (0.12 log units), on the high side, and the stated range covers the measured number.
By their numbers in this assay, from the lowest: compounds 3, 1 and 2 (each within the scatter of the next).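

Among the compounds shown here, this is the first step that isolates a single change: in this assay, 4-bromophenyl to 4-methylphenyl gives a 1.1-fold lower number from compound 1 to compound 3 (0.04 log units; within the scatter) on the shared core, so bromo and methyl cannot be told apart at this position. Compound 1 and compound 2 differ in more than one place and gave no size for any one change, whereas this swap of one heavy atom for another now has a size, and that size lies within the scatter. No supporting data bear on this result.

As far as these compounds go, with only bromo and methyl compared on this aromatic carbon, it remains open whether an amine, a carboxylic acid or a longer chain such as butyl in the same place would move the number beyond the scatter. Also open, from the compounds shown here alone, is whether methyl in place of bromo would read the same way on another cell line or at another exposure time.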